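The compounds below may be only part of what the source reports. "The series", "measured", "known", "first", "only" and "open" are said of these compounds alone.

Working notes on the series. Compound 3 `COc1ccc(/C=C\c2cc(OC)c(OC)c(OC)c2)cc1OCc1ccc(CN2CCCCC2C(=O)NCCN)cc1` reaches only a limit in an ADME assay on HEK293 cells (Homo sapiens) for cytotoxicity, read by CCK-8 assay, with a stated time of 48 h (on this read-out higher numbers stand for weaker inhibition and lower numbers for stronger inhibition), > 50000 nM. Compound 1 `COc1ccc(/C=C\c2cc(OC)c(OC)c(OC)c2)cc1OCc1ccc(CN2CC[C@@H](C(=O)O)C2)cc1` gives 27000 nM in this assay. Compound 2 `COc1ccc(/C=C\c2cc(OC)c(OC)c(OC)c2)cc1OCc1ccc(CN2CC[C@H](O)C2)cc1` likewise returns only a limit, > 50000 nM. Compound 3 therefore sits at the limit of > 50000 nM in this assay, at which 2 of the 3 values shown sit, where the read-out gives no number. The bearing steps are an at least 1.8-fold higher number from compound 1 to compound 3 (0.26 log units; that floor lies within the scatter) and a step that the two limits leave unreadable from compound 2 to compound 3; neither fixes a size. Compound 4 `COc1ccc(/C=C\c2cc(OC)c(OC)c(OC)c2)cc1OCc1ccc(CNCCN(C)C)cc1` differs from compound 3 at the saturated chain carbon bound to an aromatic carbon: (2-(dimethylamino)ethyl)amino in place of 2-((2-aminoethyl)carbamoyl)piperidin-1-yl on a saturated chain carbon bound to an aromatic carbon. Going by the values given here, no measured step opens that ring to a chain, so nothing beyond the two limits informs the change. Compound 4 is expected to stay near the limit. The step of a number no higher from compound 3 to compound 4 (the limit leaves the size open) is estimated as nominal. Compound 4 is estimated at 50000 nM, between 20000 nM and 120000 nM.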

Compound 4, half-maximal inhibitory concentration: 39000 nM
Beside the measured number, compound 4's estimate is 1.3-fold (0.11 log units) above it, within the range that was stated.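

On the saturated chain carbon bound to an aromatic carbon, (2-(dimethylamino)ethyl)amino gives a readable number in this assay, so a readable number at this position does not depend on the 3-carboxypyrrolidin-1-yl group of compound 1. Compound 2 and compound 3 remain at a limit: the limit of > 50000 nM in this assay, at which 2 of the 4 values shown sit.

The steps, an at least 1.2-fold lower number from compound 3 to compound 4 (0.10 log units; that floor lies within the scatter), an at least 1.2-fold lower number from compound 2 to compound 4 (0.10 log units; that floor lies within the scatter) and a 1.4-fold higher number from compound 1 to compound 4 (0.16 log units; within the scatter), establish no change beyond the scatter. Still open, on these data alone, is whether a longer chain, or a carboxylic acid on the open chain, would move the number beyond the scatter.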